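The source may report more compounds than this note shows. Statements on the series, on what has been measured and on what is new or still open speak of the compounds shown alone.

Working notes on the series. Compound 1 `Cc1nc(SCC(=O)Nc2nc(-c3ccc(Cl)cc3)cs2)n(Nc2ccccc2)c1C` and compound 2 `Cc1ccc(Nn2c(SCC(=O)Nc3nc(-c4ccccc4)cs3)nc(C)c2C)cc1` share a core and are both characterised in a functional assay on Malme-3M cells (Homo sapiens) for antiproliferative activity, read by sulforhodamine B assay, with a stated time of 48 h; a higher number here means a weaker inhibitor of growth, a lower number a stronger inhibitor of growth. In this assay, within the data shown here, compound 1 gives 37600 nM, the highest of the two numbers known, while compound 2 gives 13600 nM, a lower number beyond the usual scatter; compound 2 differs from compound 1 in more than one place, so the two values show only that compound 2 sits lower. Compound 3 `COc1ccc(Nn2c(SCC(=O)Nc3nc(-c4ccc(Cl)cc4)cs3)nc(C)c2C)cc1` is still to be measured. It departs from compound 1 by methoxy in place of hydrogen on an aromatic carbon, the methoxy group entering para to a large group on the six-membered aromatic ring of carbon only, with the rest of compound 1 kept. Among the measured compounds shown here, no single-change step is known in this set, so the size of the move cannot be read from a measured pair. A small step toward a lower number is expected, of about a 1.7-fold lower number from compound 1 to compound 3 (0.23 log units; within the scatter), possibly within the scatter. Compound 3 is estimated at 22000 nM, within a range from 7000 nM to 60000 nM.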

Compound 3, concentration for total growth inhibition: > 100000 nM
Compound 3 ended at the assay's limit; the forecaster's own chance of this, stated with the estimate: 5%; middle value at least 4.5-fold (0.65 log units) from the limit.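

Among these compounds, the change from anilino to (4-methoxyphenyl)amino gives the only single-change reading: in this assay it amounts to an at least 2.6-fold higher number from compound 1 to compound 3 (0.42 log units; beyond the scatter). For compound 3 the value of > 100000 nM is a limit of the assay, not a number. At this position, para to a large group and with the rest of compound 1 kept, methoxy therefore goes with weaker inhibition of growth rather than stronger, and the full size of the step stays unread past the limit: the limit of > 100000 nM in this assay, at which 1 of the 3 values shown sits.

From the compounds shown here alone, it remains open whether fluoro, hydroxy or dimethylamino in the same place would shift the number in the same direction as methoxy. Also open, going by these compounds, is whether methoxy at this position moves the number the same way on a compound lacking the chlorine of compound 1.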